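The source may hold more compounds than are shown below. What is called first, only, known or untested is meant among the compounds shown, and "the series" means these compounds.

Measured compounds in a functional assay on PC-3 cells (Homo sapiens) for antiproliferative activity, read by MTT assay, with a stated time of 48 h; a higher number here means a weaker inhibitor, a lower number a stronger inhibitor:

compound 1, `COc1ccc(/C=C/C(=O)c2cc(OC)c(OC)c(OC)c2)cc1OCCCC(=O)NCCCCN(CCCN)CCCCNCCCN` — 48100 nM
compound 2, `COc1cc(C(=O)/C=C/c2ccc(OCCCC(=O)NCCCCNCCCN)cc2)cc(OC)c1OC` — 79300 nM
compound 3, `COc1ccc(/C=C/C(=O)c2cc(OC)c(OC)c(OC)c2)cc1OCCCC(=O)NCCCCNCCCN` — 51000 nM

Compounds 1 and 3 share one core; compound 2 carries the other, and the difference between the two cores is not broken down here. The three measured values sit close together: compound 2 gives the highest number of the three, but its gaps to compound 3 and to compound 1 are both within the usual scatter of the method, so no ordering among them is claimed.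

One structural change is seen twice in the set. From compound 3 to compound 1 it is 4-((3-aminopropyl)amino)butyl in place of hydrogen on an amine nitrogen, and it gave a 1.1-fold lower number from compound 3 to compound 1 (0.03 log units; within the scatter). The same change, made on the core of compound 2, leads to compound 4, `COc1cc(C(=O)/C=C/c2ccc(OCCCC(=O)NCCCCN(CCCN)CCCCNCCCN)cc2)cc(OC)c1OC`, the unmeasured member: 4-((3-aminopropyl)amino)butyl in place of hydrogen on an amine nitrogen. The two place descriptions agree word for word, so the change is taken as the same one, only on the other core.

Among the compounds with values here, the expectation for compound 4 rests on the single precedent. Because a 1.1-fold lower number from compound 3 to compound 1 (0.03 log units; within the scatter) was within scatter, the step from compound 2 to compound 4 is estimated as a 1.1-fold lower number from compound 2 to compound 4 (0.04 log units; within the scatter), that is, essentially no movement. Compound 4 is therefore expected near compound 2, with an estimate of 72000 nM in this assay and a likely range from 35000 nM to 150000 nM. Whether the second core responds to the change as the first one did is exactly what the measurement will show.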

Compound 4, half-maximal inhibitory concentration: 81600 nM
Compound 4: the middle estimate sits 1.1-fold (0.05 log units) below what was measured; measured number inside the range.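

In this assay, 4-((3-aminopropyl)amino)butyl in place of hydrogen on an amine nitrogen gives a 1.0-fold higher number from compound 2 to compound 4 (0.01 log units; within the scatter), so on this core too the change produces no movement that can be told from the scatter. Set beside the earlier step, the change carries from one core to the other without a detectable difference: the same change on two cores in this assay, a 1.1-fold lower number (0.03 log units; within the scatter) from compound 3 to compound 1 and a 1.0-fold higher number (0.01 log units; within the scatter) from compound 2 to compound 4, 1.1-fold (0.04 log units) apart, within the scatter of two such steps. This shows that the change leaves the read-out unmoved on both cores, but it rests on one pair per core in a single assay, and with both steps inside the scatter there is no effect of measurable size to transfer, so it does not show that the same would hold on any further core.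

The compounds shown leave open what happens on the same amine nitrogen with other groups, such as a simple methyl, an acetyl, a carboxylic acid or a longer chain carrying further amines. Also open, going by these compounds, is whether the two cores would still match with a shorter or longer chain in place of the one joining the amide to the ring oxygen, and whether they would match in any read-out other than this assay.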